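Dichlorobenzyl Swap on a Pyrazole Hydroxamate Ester

This account rests on a few compounds, and the source may have more. Where it says the series, first, only, none or still open, it means among the compounds named here.

Measured compounds:
- compound 1, `O=C(NOCc1ccc(Cl)cc1Cl)c1cn(-c2ccccc2)nc1-c1ccccc1`: 7350 nM
- compound 2, `O=C(NOCc1ccccc1)c1cn(-c2ccccc2)nc1-c1ccc(F)cc1`: 10400 nM

In a functional assay on A549 cells (Homo sapiens) for antiproliferative activity, read by MTT assay, with a stated time of 48 h, in the presence of a further agent that is not named here (on this read-out lower numbers stand for stronger inhibition of growth and higher numbers for weaker inhibition of growth), compound 2 gives 10400 nM, the higher of the two numbers, while compound 1 gives 7350 nM, and the two values lie within the scatter of each other, so no order can be read between them. Compound 3, `O=C(NOCc1ccc(Cl)cc1Cl)c1cn(-c2ccccc2)nc1-c1ccc(F)cc1`, is derived from compound 2 by the change (2,4-dichlorophenyl in place of phenyl on a saturated chain carbon bound to an oxygen). For the measured compounds named here, compound 1 already carries the 2,4-dichlorobenzyl group but differs from compound 3 in a further place as well, so no measured pair isolates this change. With compound 1 and compound 2 so close in this assay, the step from compound 2 to compound 3 is expected to be small, at most a modest lowering that need not exceed the scatter, a 1.6-fold lower number from compound 2 to compound 3 (0.20 log units; within the scatter). Compound 3 is therefore estimated at 6500 nM, in the range 2500 nM to 17000 nM.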

Compound 3, concentration for 50% growth inhibition: 14000 nM
The estimate for compound 3 lay 2.2-fold (0.33 log units) below the measured number, and the stated range covers the measured number.
By their numbers in this assay, from the lowest: compounds 1, 2 and 3 (each within the scatter of the next).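

The swap of phenyl for 2,4-dichlorophenyl on a saturated chain carbon bound to an oxygen now has a measured pair in this assay and reads a 1.3-fold higher number from compound 2 to compound 3 (0.13 log units; within the scatter) so this position tolerates the added chlorine atoms without a step that can be told from the scatter. The same compound gives a second pair, fluoro in place of hydrogen on an aromatic carbon, which reads a 1.9-fold higher number from compound 1 to compound 3 (0.28 log units; within the scatter) and so also stays inside the scatter. No measurement is available that would account for either step.

Open, going by these compounds, is whether a longer chain in place of benzyl, or an amine or a carboxylic acid in place of the chlorine atoms, would give a number beyond the scatter in this assay at this position. On these data alone, each change also rests on a single pair, so its size on another core remains unknown.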